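The compounds below may be only part of what the source reports. "The series", "measured", "known", "first", "only" and "open" are said of these compounds alone.

Compound 1, `O=C1COc2ccc(-c3cnc(Cl)c(NS(=O)(=O)c4ccc(F)cc4)c3)cc2N1C1CCCCC1`, was tested in a functional assay on HepG2 cells (Homo sapiens) for antiproliferative activity, read by MTT assay, with a stated time of 72 h; a higher number here means a weaker inhibitor, a lower number a stronger inhibitor. In this assay compound 1 reaches only the limit of the assay, > 40000 nM. Compound 2, `COc1ncc(-c2ccc3c(c2)N(C2CCCCC2)C(=O)CO3)cc1NS(=O)(=O)c1ccc(F)cc1`, also gives only a limit in this assay, > 40000 nM. The step that the two limits leave unreadable from compound 1 to compound 2 therefore cannot be sized. Compound 3, `COc1ncc(-c2ccc3c(c2)NC(=O)CO3)cc1NS(=O)(=O)c1ccc(F)cc1`, gives 6590 nM in this assay, and the step of an at least 6.0-fold lower number from compound 2 to compound 3 (0.78 log units; beyond the scatter) is the one readable step among these compounds. Compound 4, `COc1ccc(N2C(=O)COc3ccc(-c4cnc(Cl)c(NS(=O)(=O)c5ccc(F)cc5)c4)cc32)cc1`, differs from compound 1 by 4-methoxyphenyl in place of cyclohexyl on an amide-type nitrogen in a ring. The weight of evidence is the limit of > 40000 nM in this assay, at which 2 of the 3 values shown sit, and only compound 3, carrying hydrogen on that nitrogen, reads as a number. Compound 4 keeps a substituent on that nitrogen, as compound 1 and compound 2 do, and the expected step of a number no higher from compound 1 to compound 4 (the limit leaves the size open) is small. Compound 4 is estimated at 40000 nM, with a range from 15000 nM to 100000 nM, and another limit is likely.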

Compound 4, half-maximal inhibitory concentration: > 40000 nM
Compound 4 ended at the assay's limit; the forecaster's own chance of this, stated with the estimate: 70%; the middle value sits exactly at the limit.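

Compound 1 and compound 4 both give only a limit in this assay, so no step can be read between them: the limit of > 40000 nM in this assay, at which 3 of the 4 values shown sit.

The compounds shown leave open how 4-methoxyphenyl and cyclohexyl on that nitrogen actually compare.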